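Hep 3B2 series: aryl swap on the ring nitrogen

This account rests on a few compounds, and the source may have more. Where it says the series, first, only, none or still open, it means among the compounds named here.

Measured compounds:
Compound 1 `C[C@H](Nc1ncnc2[nH]cnc12)c1nn(-c2ccncc2)c2cc(F)ccc12`: 21400 nM
Compound 2 `CC[C@H](Nc1ncnc2[nH]cnc12)c1nn(-c2cccnc2)c2cc(F)ccc12`: limit, > 40000 nM

Within the data shown here, in a functional assay on Hep 3B2 cells (Homo sapiens) for inhibition, read by sulforhodamine B assay, with a stated time of 72 h (on this read-out higher numbers stand for weaker inhibition and lower numbers for stronger inhibition), compound 1 gives 21400 nM, the only number in the set. Compound 2 reaches only the limit of > 40000 nM in this assay. Among the measured compounds shown here, compound 1 therefore stands as the one compound with a defined value, and that value is weak, with the limit of > 40000 nM in this assay, at which 1 of the 2 values shown sits, marking the other entry.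

Compound 3 `C[C@H](Nc1ncnc2[nH]cnc12)c1nn(-c2cccc(F)c2)c2cc(F)ccc12` is unmeasured. It differs from compound 1 by 3-fluorophenyl in place of pyridin-4-yl on an aromatic nitrogen. With no measured step of this kind in the set, the expected step from compound 1 to compound 3 is a 1.1-fold lower number from compound 1 to compound 3 (0.03 log units; within the scatter), in either direction, not beyond the scatter. Compound 3 is estimated at 20000 nM, between 7000 nM and 60000 nM.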

Compound 3, half-maximal inhibitory concentration: > 40000 nM
Compound 3 was reported as a limit; the forecaster's own chance of this, stated with the estimate: 35%; middle value at least 2.0-fold (0.30 log units) away from the limit.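

In this assay compound 3 gives > 40000 nM as a limit, not a number. On this aromatic nitrogen, 3-fluorophenyl in place of pyridin-4-yl gives an at least 1.8-fold higher number from compound 1 to compound 3 (0.27 log units; that floor lies within the scatter) and so brings no gain in inhibition, while the true size of the step cannot be read. The carbon-only aryl group joins the capped end of this small set: the limit of > 40000 nM in this assay, at which 2 of the 3 values shown sit. Still open, on these data alone, are how far compound 3 lies past its limit and whether an aryl group carrying an amine or a carboxylic acid at this nitrogen gives a defined value.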